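Isobutyl for Methyl on the Thiadiazole of Compound 1

The source may hold more compounds than are shown below. What is called first, only, known or untested is meant among the compounds shown, and "the series" means these compounds.

Compound 1 `Cc1nnc(-c2ccc(N3CCC(Oc4ccccc4C(F)(F)F)CC3)nn2)s1` gives 2.3 nM in an assay on microsomes from liver for inhibition of acyl-CoA desaturase 1 (Rattus norvegicus) (on this read-out lower numbers stand for stronger inhibition and higher numbers for weaker inhibition), the lowest of the three numbers; compound 3 `c1cn(-c2ccc(N3CCC(Oc4ccc5c(c4)CCC5)CC3)nn2)cn1` gives 62 nM and compound 2 `COc1ccccc1OC1CCN(c2ccc(-n3ccnc3)nn2)CC1` gives 543 nM. Among the compounds with values here, the one step between measured compounds is an 8.8-fold lower number from compound 2 to compound 3 (0.94 log units; beyond the scatter), a change of the aryl group on the ether oxygen, not of the thiadiazole substituent. Compound 4 `CC(C)Cc1nnc(-c2ccc(N3CCC(Oc4ccccc4C(F)(F)F)CC3)nn2)s1` differs from compound 1 in isopropyl in place of hydrogen on a saturated chain carbon bound to an aromatic carbon. Within the data shown here, no measured step speaks to this change, so compound 4 is expected to sit near compound 1, with a step of a 1.7-fold higher number from compound 1 to compound 4 (0.24 log units; within the scatter) likely within the scatter or a slight weakening. Compound 4 is estimated at 4 nM, between 1 nM and 15 nM.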

Compound 4, half-maximal inhibitory concentration: 37 nM
The estimate for compound 4 lay 9.3-fold (0.97 log units) below the measured number; the whole stated range lies below it.
By their numbers in this assay, from the lowest: compound 1; then compounds 4 and 3 (each within the scatter of the next); then compound 2.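

In this assay, the change from 5-methyl-1,3,4-thiadiazol-2-yl to 5-isobutyl-1,3,4-thiadiazol-2-yl gives a 16-fold higher number from compound 1 to compound 4 (1.21 log units; beyond the scatter), the first step read at this position. The number therefore depends on the group carried by the thiadiazole, and methyl is the better of the two groups shown here. No measurement at hand accounts for this step.

With only methyl and isobutyl shown, it remains open whether an ethyl or an unbranched butyl chain would keep the number of compound 1. As far as these compounds go, how an amine or a carboxylic acid on this chain would read also remains open.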